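The source may hold more compounds than are shown below. What is called first, only, known or untested is meant among the compounds shown, and "the series" means these compounds.

Measured so far:
compound 1 `ClCc1ccc(Cn2cnc3c(Cl)ncnc32)cc1` — 3380 nM
compound 2 `ClCc1ccccc1Cn1cnc2c(Cl)nc(Cl)nc21` — 1820 nM

In a functional assay on SK-OV-3 cells (Homo sapiens) for cytotoxicity, read by sulforhodamine B assay, with a stated time of 48 h (a higher number here means a weaker inhibitor of growth, a lower number a stronger inhibitor of growth), compound 2 gives 1820 nM, and compound 1 gives 3380 nM; the gap between the two lies within the scatter, so nothing separates compound 2 from compound 1 on these numbers. Compound 3 `ClCc1ccccc1Cn1cnc2c(Cl)ncnc21` has not been measured. It differs from compound 2 by hydrogen in place of chloro on an aromatic carbon. Within the data shown here, no measured pair shows this change, so its size is open; the expectation is a small step, if any, toward a higher number in this assay, of the order of a 1.6-fold higher number from compound 2 to compound 3 (0.22 log units; within the scatter). Compound 3 is therefore estimated at 3000 nM, within 1200 nM to 8000 nM.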

Compound 3, concentration for 50% growth inhibition: 4170 nM
Estimate against measurement, compound 3: 1.4-fold (0.14 log units) below; the range from low to high includes it.
By their numbers in this assay, from the lowest: compounds 2, 1 and 3 (each within the scatter of the next, the first and the last beyond it).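

In this assay hydrogen in place of chloro on the aromatic carbon between two ring nitrogen atoms gives a 2.3-fold higher number from compound 2 to compound 3 (0.36 log units; beyond the scatter) and is thus a modest change beyond the scatter. Among these compounds, this is the first reading at this position, and it shows that the chloro group there is not neutral for growth inhibition in this pair. Nothing measured accounts for the step. As far as these compounds go, whether an amine or a methoxy group on this carbon would give a lower or a higher number remains open. From the compounds shown here alone, whether the step holds in other cell lines is also open.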